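This account rests on a few compounds, and the source may have more. Where it says the series, first, only, none or still open, it means among the compounds named here.

The compounds here share one core and differ only in the group carried on a nitrogen attached to that core. Compound 1 `CCCCNc1oc2c(C)ncc(CO)c2c1Nc1ccccn1` carries a butyl chain, and in a functional assay on HEK293 cells for agonist activity at Toll-like receptor 8 (Homo sapiens), read by reporter gene assay (on this read-out lower numbers stand for an effect already at smaller amounts and higher numbers for an effect only at larger amounts of compound), compound 1 gives 9380 nM. Compound 2 `Cc1ncc(CO)c2c(Nc3ccccn3)c(NC(C)C)oc12` carries an isopropyl group, and in this assay compound 2 is recorded as "not active" (no number reported), with no number behind it. Compound 3 `Cc1ncc(CO)c2c(Nc3ccccn3)c(NC(C)(C)CC(C)(C)C)oc12` carries a 1,1,3,3-tetramethylbutyl group, and in this assay compound 3 is likewise recorded as "not active" (no number reported), so no single number exists for it and it cannot be placed on a scale against compound 1. Compound 4 `Cc1ncc(CO)c2c(Nc3ccccn3)c(NC3CCCCC3)oc12` is the unmeasured partner of compound 3; the change is cyclohexyl in place of 1,1,3,3-tetramethylbutyl on a nitrogen on an aromatic ring. Among the compounds with values here, no measured pair shows how much such a swap matters here, and since compound 3 has no number, no direction can be read from it; the only numbered compound, compound 1, sits at a large concentration, and two of three recorded compounds gave no number at all. Compound 4 is therefore expected to give a weak result or none, estimated at 20000 nM with a range from 5000 nM to 100000 nM.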

Compound 4, half-maximal effective concentration: 6930 nM
For compound 4 the middle estimate is 2.9-fold (0.46 log units) above the measured one; measured number inside the range.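

In this assay compound 4 gives a single number, 6930 nM, so a substituent on this nitrogen on an aromatic ring can carry a six-membered ring of carbon and still register an effect, whereas compound 3 has no number and any step from it to compound 4 cannot be read. Set against the open butyl chain, cyclohexyl gives a 1.4-fold lower number from compound 1 to compound 4 (0.13 log units; within the scatter), so these two groups cannot be told apart on this read-out. Nothing available explains why compound 4 gives a number and compound 3 does not.

Going by these compounds, whether a longer straight chain such as hexyl, a smaller ring such as cyclopentyl, or a benzyl group would behave like butyl and cyclohexyl stays open. Also open, on these data alone, is whether any group at this place, such as a chain ending in an amine, could give a much smaller number.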